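The source may hold more compounds than are shown below. What is called first, only, known or untested is meant among the compounds shown, and "the series" means these compounds.

Working notes on the series. In a functional assay on MNK45 cells (Homo sapiens) for inhibition, read by MTT assay, with a stated time of 48 h (a higher number here means a weaker inhibitor, a lower number a stronger inhibitor), compound 1 `Cc1ccc(NC(=O)NC(=O)c2ccc(OCc3ccccc3)cc2)cc1-c1nc2ccccc2[nH]1` gives 35100 nM and compound 2 `Cc1ccc(NC(=O)NC(=O)c2ccc(OCc3cccc(Cl)c3)cc2)cc1-c1nc2ccccc2[nH]1` gives 28000 nM; the step of a 1.3-fold lower number from compound 1 to compound 2 (0.10 log units; within the scatter) stays within the scatter. Compound 3 `Cc1ccc(COc2ccc(C(=O)NC(=O)Nc3ccc(C)c(-c4nc5ccccc5[nH]4)c3)cc2)cc1` gives 6360 nM and so stands lowest of the three numbers, with steps a 5.5-fold lower number from compound 1 to compound 3 (0.74 log units; beyond the scatter) and a 4.4-fold lower number from compound 2 to compound 3 (0.64 log units; beyond the scatter) both beyond the scatter. Compound 4 `Cc1ccc(NC(=O)NC(=O)c2ccc(OCc3cccc(F)c3)cc2)cc1-c1nc2ccccc2[nH]1` differs from compound 3 only by 3-fluorophenyl in place of 4-methylphenyl on a saturated chain carbon bound to an oxygen on an aromatic ring. The step from compound 2 to compound 3 bears on this most directly, and the step from compound 1 to compound 2 shows that a halogen at that place changes little. Compound 4 is therefore expected to land near compounds 1 and 2, an expected step of a 3.9-fold higher number from compound 3 to compound 4 (0.59 log units; beyond the scatter). For compound 4 the estimate in this assay is 25000 nM, ranging from 10000 nM to 60000 nM.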

Compound 4, half-maximal inhibitory concentration: 53000 nM
For compound 4 the middle estimate is 2.1-fold (0.33 log units) below the measured one; the range from low to high includes it.
By their numbers in this assay, from the lowest: compound 3; then compounds 2, 1 and 4 (each within the scatter of the next).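

In this assay, fluoro joins hydrogen and chloro among the groups that leave the number essentially unmoved on this ring: a 1.5-fold higher number from compound 1 to compound 4 (0.18 log units; within the scatter) and a 1.9-fold higher number from compound 2 to compound 4 (0.28 log units; within the scatter) both stay within the scatter. The step of an 8.3-fold higher number from compound 3 to compound 4 (0.92 log units; beyond the scatter) lies beyond the scatter, so among these four compounds only the 4-methylphenyl of compound 3 stands apart at this place. No data at hand explain that gap.

From the compounds shown here alone, whether the gap belongs to the methyl group itself or to where it sits on the ring stays open, since compound 3 alone carries it. Also open, going by these compounds, is how an ethyl, a methoxy or an amine on this ring would read.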